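Swapping 2-cyanoethyl for 2-cyanoethenyl on the shared core

This account rests on a few compounds, and the source may have more. Where it says the series, first, only, none or still open, it means among the compounds named here.

- compound 1 `Cc1cc(/C=C/C#N)cc(C)c1Oc1cc(Nc2ccc(C#N)cc2)c(N)cc1[N+](=O)[O-]` - 0.797 h
- compound 2 `Cc1cc(CCC#N)cc(C)c1Oc1cc(Nc2ccc(C#N)cc2)c(N)cc1CO` - 0.348 h

In an in vitro ADME assay on microsomes from liver (Homo sapiens) for metabolic stability, tested at 1 uM (on this read-out lower numbers stand for a shorter-lived compound and higher numbers for a longer-lived compound), compound 2 gives the lower of the two numbers, 0.348 h, and its gap to compound 1 lies beyond the usual scatter. Compound 3 `Cc1cc(/C=C/C#N)cc(C)c1Oc1cc(Nc2ccc(C#N)cc2)c(N)cc1CO` differs from compound 2 in one place: 2-cyanoethenyl in place of 2-cyanoethyl on an aromatic carbon. Among the compounds with values here, no measured pair isolates this change. Compound 1 also carries 2-cyanoethenyl and gives 0.797 h, so a small rise in this assay is expected, probably not beyond the scatter. The expected step is a 1.3-fold higher number from compound 2 to compound 3 (0.11 log units; within the scatter). For compound 3 the estimated half-life is 0.45 h, with an expected range of 0.22 h to 0.9 h.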

Compound 3, half-life: 0.503 h
Estimate against measurement, compound 3: 1.1-fold (0.05 log units) below; low and high end bracket the measured number.
By their numbers in this assay, from the lowest: compounds 2, 3 and 1 (each within the scatter of the next, the first and the last beyond it).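

In this assay, the change on this aromatic carbon gives a 1.4-fold higher number from compound 2 to compound 3 (0.16 log units; within the scatter) and so does not separate 2-cyanoethenyl from 2-cyanoethyl. With 2-cyanoethenyl in place, hydroxymethyl in place of nitro gives a 1.6-fold lower number from compound 1 to compound 3 (0.20 log units; within the scatter) and does not separate those two groups either. Nothing on hand gives a cause for either step. From the compounds shown here alone, whether a longer chain or a carboxylic acid on this aromatic carbon would move the half-life beyond the scatter remains open. The same question stands for an amine in place of hydroxymethyl.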